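The source may report more compounds than this note shows. Statements on the series, on what has been measured and on what is new or still open speak of the compounds shown alone.

In an assay on isolated protein for binding affinity to somatostatin receptor type 3 (Homo sapiens) (on this read-out lower numbers stand for tighter binding and higher numbers for weaker binding), compound 1, whose structure is `COC(=O)c1cc(CC(C)CN2CC3CCCCC3C(C(=O)N3CCN(c4ccc([N+](=O)[O-])cc4)CC3)C2)cc(C(=O)OC)c1`, gives 2.88 nM. Compound 2, drawn as `COC(=O)c1cc(CC(C)CN2C[C@@H]3CCCC[C@@H]3[C@H](C(=O)N3CCN(c4ccc([N+](=O)[O-])cc4)CC3)C2)cc(C(=O)OC)c1`, gives 1.35 nM in this assay; the step of a 2.1-fold lower number from compound 1 to compound 2 (0.33 log units; beyond the scatter) is the only measured step among these compounds, and it goes with the fact that one of compounds 1 and 2 is drawn with a defined configuration and the other without, at the place where they differ. Compound 3, with the structure `C[C@@H](Cc1ccc2ocnc2c1)CN1C[C@@H]2CCCC[C@@H]2[C@H](C(=O)N2CCN(c3ccc(F)c(F)c3)CC2)C1`, gives 11 nM in this assay, the highest of the three numbers, so it binds less tightly than compound 1 and compound 2.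

Compound 4, `Cc1nc2cc(C[C@H](C)CN3C[C@@H]4CCCC[C@@H]4[C@H](C(=O)N4CCN(c5ccc(F)c(F)c5)CC4)C3)ccc2o1`, differs from compound 3 in one place: methyl in place of hydrogen on an aromatic carbon. Among the measured compounds shown here, no measured step involves a methyl group added to an aromatic ring, so the one known step, which concerns stereochemistry only, does not bear on this change. For a single methyl group, with nothing measured to point either way, no step beyond the scatter is expected in this assay. Compound 4 is therefore expected to give 10 nM, within a range of 4 nM to 25 nM. The expected step of a 1.1-fold lower number from compound 3 to compound 4 (0.04 log units; within the scatter) lies within the usual scatter.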

Compound 4, dissociation constant: 3.39 nM
Beside the measured number, compound 4's estimate is 2.9-fold (0.47 log units) above it, outside the stated range (below it).
By their numbers in this assay, from the lowest: compound 2; then compounds 1 and 4 (each within the scatter of the next); then compound 3.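

Going from 1,3-benzoxazol-5-yl to 2-methyl-1,3-benzoxazol-5-yl gives a 3.2-fold lower number from compound 3 to compound 4 (0.51 log units; beyond the scatter) in this assay, so this carbon is a place where a single added methyl moves the read-out beyond the scatter, towards tighter binding. Among the compounds shown here, the only earlier step concerned how stereochemistry is drawn, so this is the first sign that the aromatic end of the molecule, and not just the configuration of the core, affects binding here. The one available explanatory fact concerns configuration and does not bear on this methyl change, so the reason for the step remains unknown.

From the compounds shown here alone, with only hydrogen and methyl compared on this carbon, it remains open how an ethyl group, a longer chain, an amine or a carboxylic acid would behave there. Going by these compounds, it is also open whether methyl would give a similar step on another aromatic carbon of the ring system.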